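This account rests on a few compounds, and the source may have more. Where it says the series, first, only, none or still open, it means among the compounds named here.

Measured compounds in an assay on isolated protein for displacement of a labelled ligand from Oxytocin receptor (Homo sapiens); on this read-out higher numbers stand for weaker inhibition and lower numbers for stronger inhibition:

compound 1 `CC[C@H](C)[C@@H]1C(=O)N[C@H](C2Cc3ccccc3C2)C(=O)N1[C@@H](C(=O)N1CCOCC1)c1cnc(C)cc1C`, 0.0501 nM
compound 2 `CCC(CC)[C@@H]1C(=O)N[C@H](C2Cc3ccccc3C2)C(=O)N1[C@@H](C(=O)N1CCOCC1)c1ccc(C)nc1`, 0.0251 nM
compound 3 `CC[C@H](C)[C@@H]1C(=O)N[C@H](C2Cc3ccccc3C2)C(=O)N1[C@@H](C(=O)N1CCOCC1)c1cc(C)cnc1C`, 0.794 nM

Compound 1 stands second highest of the three numbers. Its nearest neighbour is compound 2, whose value lies within the scatter of that of compound 1, so no order between the two is claimed. Compound 3 is the furthest: the step of a 16-fold higher number from compound 1 to compound 3 (1.20 log units; beyond the scatter) is large and beyond the scatter, and it comes from a change on the pyridine ring, not on the amide end of the core.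

Compound 4 `CC[C@H](C)[C@@H]1C(=O)N[C@H](C2Cc3ccccc3C2)C(=O)N1[C@@H](C(=O)N(C)C)c1cnc(C)cc1C` differs from compound 1 at the other end of the molecule: dimethylamino in place of morpholin-4-yl on a carbonyl carbon. Among the measured compounds shown here, no measured step in this set touches the amide end, so the single known step gives no direct guide; it only shows that the shared core tolerates changes of quite different size. The change from a ring to an open chain at the carbonyl is expected to cost some affinity, with a shift a 3.0-fold higher number from compound 1 to compound 4 (0.48 log units; beyond the scatter) that may reach the edge of the scatter. Compound 4 is therefore estimated at 0.15 nM, in the range 0.04 nM to 0.6 nM.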

Compound 4, inhibition constant: 0.0398 nM
The estimate for compound 4 lay 3.8-fold (0.58 log units) above the measured number; the whole stated range lies above it.
By their numbers in this assay, from the lowest: compounds 2, 4 and 1 (each within the scatter of the next); then compound 3.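

In this assay, the step (a 1.3-fold lower number from compound 1 to compound 4 (0.10 log units; within the scatter)) shows that dimethylamino can stand in place of morpholin-4-yl on a carbonyl carbon with no readable difference. Among the compounds shown here, this is the first read at the amide end of the series: the six-membered non-aromatic ring goes, the 6 heavy atoms of morpholin-4-yl give way to the 3 of dimethylamino, and the result stays within the scatter, unlike the large step on the pyridine ring (a 16-fold higher number from compound 1 to compound 3 (1.20 log units; beyond the scatter)). No available evidence bears on why this swap leaves the number unresolved from that of compound 1.

Open, going by these compounds, is whether diethylamino, piperazin-1-yl or a primary amine on this carbonyl carbon would also stay within the scatter. Also open, on these data alone, is whether the same swap holds on the background of compound 2 or compound 3, as this is a single step on the background of compound 1.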